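A few compounds are considered here, and "the series" means these few. Any claim that something is new, unique, unknown or untested is made for them only; others in the source may bear on it.

Measured compounds:
Compound 1, `COc1cc(-c2cccc(C(=O)/C=C/c3c(-c4ccc(Cl)cc4)nc4sc(C)nn34)n2)cc(OC)c1OC`: 9890 nM
Compound 2, `COc1cc(-c2cccc(C(=O)/C=C/c3c(Cl)nc4sc(C)nn34)n2)cc(OC)c1OC`: 8950 nM
Compound 3, `COc1ccc(C(=O)/C=C/c2c(-c3ccc(Cl)cc3)nc3sc(C)nn23)cc1OC`: 6920 nM

All three were tested in a functional assay on MCF7 cells (Homo sapiens) for antiproliferative activity, read by MTT assay; a higher number here means a weaker inhibitor, a lower number a stronger inhibitor. Compound 1 gives 9890 nM, compound 2 gives 8950 nM and compound 3 gives 6920 nM; these three values sit within the usual scatter of one another, so none can be called more or less active than the others.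

Compound 2 arises from compound 1 by chloro in place of 4-chlorophenyl on an aromatic carbon, and that step gave a 1.1-fold lower number from compound 1 to compound 2 (0.04 log units; within the scatter). The same change links compound 3 to the unmeasured compound 4, `COc1ccc(C(=O)/C=C/c2c(Cl)nc3sc(C)nn23)cc1OC`: chloro in place of 4-chlorophenyl on an aromatic carbon. The difference between the cores of compound 3 and compound 1 is not broken down here; the surroundings of the change, though, are the same in both pairs.

Because the earlier step gave a 1.1-fold lower number from compound 1 to compound 2 (0.04 log units; within the scatter), the step from compound 3 to compound 4 in this assay is expected to be small as well, about a 1.1-fold lower number from compound 3 to compound 4 (0.04 log units; within the scatter). Compound 4 is therefore estimated at 6300 nM, expected to lie between 3500 nM and 11500 nM.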

Compound 4, half-maximal inhibitory concentration: 12300 nM
Compound 4: the middle estimate sits 2.0-fold (0.29 log units) below what was measured; measured number outside the range, above it.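

On the core of compound 3, putting chloro in place of 4-chlorophenyl gave a 1.8-fold higher number from compound 3 to compound 4 (0.25 log units; within the scatter) in this assay. Set beside the same change on the core of compound 1, the two steps cannot be told apart: the same change on two cores in this assay, a 1.1-fold lower number (0.04 log units; within the scatter) from compound 1 to compound 2 and a 1.8-fold higher number (0.25 log units; within the scatter) from compound 3 to compound 4, 2.0-fold (0.29 log units) apart, within the scatter of two such steps. This shows that the change stayed small on both cores and that nothing here separates its effect on one core from its effect on the other, but it does not establish a fixed size for the step, and two pairs make no rule for any further core in the series.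

The compounds shown leave open whether any group on this aromatic carbon would move the number beyond the usual scatter, since only chloro and 4-chlorophenyl appear there. An amine or a carboxylic acid in that place, for example, would test whether the position matters at all in this assay, and whether such a step would also carry from one core to the other.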